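Bromo in place of a thiophene ring on a pyrazole scaffold

The source may hold more compounds than are shown below. What is called first, only, known or untested is meant among the compounds shown, and "the series" means these compounds.

Of the compounds shown here, two from this study have been measured in a physicochemical assay, read by spectrophotometry, with a stated time of 30 min; a higher number here means a weaker inhibitor, a lower number a stronger inhibitor. Compound 1 `COc1ccc(-c2c(C)nn(-c3ccccc3)c2OC)cc1` gives 25 ug/mL. Compound 2 `COc1c(-c2ccsc2)c(C)nn1-c1ccccc1` gives 30.1 ug/mL. On these two numbers compound 2 cannot be separated from compound 1: the gap between them lies within the scatter of repeated measurements, so neither can be called stronger or weaker than the other.

Compound 3 `COc1c(Br)c(C)nn1-c1ccccc1` has not yet been measured in this assay. It differs from compound 2 in one place: bromo in place of thiophen-3-yl on an aromatic carbon. The core and the phenyl group, methyl group and methoxy group around the site of change are the same in both compounds.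

Within the data shown here, no measured pair in the study shows the effect of such a change, so the size of the step cannot be read from the data. Compound 3 is expected to give a number in the same region as compound 2, with a modest weakening the more likely direction, estimated as 40 ug/mL within a range of 15 ug/mL to 110 ug/mL. The expected step from compound 2 to compound 3 is a 1.3-fold higher number from compound 2 to compound 3 (0.12 log units; within the scatter), which may not exceed the scatter.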

Compound 3, half-maximal inhibitory concentration: 37 ug/mL
Estimate against measurement, compound 3: 1.1-fold (0.03 log units) above; measured number inside the range.
By their numbers in this assay, from the lowest: compounds 1, 2 and 3 (each within the scatter of the next).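

The replacement of thiophen-3-yl by bromo on this aromatic carbon gives, in this assay, a 1.2-fold higher number from compound 2 to compound 3 (0.09 log units; within the scatter), and this is the only reading of a single change at this position among the compounds shown. A whole five-membered aromatic ring with its sulfur and its hydrogen-bond acceptor leaves, a single bromine atom enters, and the two compounds still cannot be separated in this assay, so the read-out gives no sign that this ring is required at this position. No supporting measurement bears on this result.

From the compounds shown here alone, with a single step at this position, it stays open whether this assay would separate compound 2 from a compound carrying an amine, a carboxylic acid or a longer alkyl chain on the same aromatic carbon. The phenyl, methyl and methoxy groups around the site are the same in compound 2 and compound 3, so what each contributes to these numbers cannot be read from this pair.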